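The compounds below may be only part of what the source reports. "The series", "measured", "known", "first", "only" and "open" are said of these compounds alone.

Measured compounds: compound 1 `Brc1ccc(-n2cc(CSc3nc4ccccc4s3)nn2)cc1` gives 75%, compound 2 `O=[N+]([O-])c1ccc(-n2cc(CSc3nc4ccccc4s3)nn2)cc1` gives 75%, and compound 3 `CCOc1ccc(-n2cc(CSc3nc4ccccc4s3)nn2)cc1` gives 38.3% in a functional assay on the whole organism (strain Albino Wistar) for inhibition, with Rattus norvegicus as the target, read by paw edema, with stated times of 1 h and 3 h, at a dose of 10 mg/kg by the oral route; a higher number here means more inhibition at the dose given (going by the name of the read-out), a lower number less inhibition.

Compound 1 stands level with compound 2, and the two share the highest numbers of the three; compound 3 lies far lower, as the step of a number 36.7 percentage points lower from compound 1 to compound 3 (beyond the scatter) shows. Compound 4 `OCC(O)Cn1cc(CSc2nc3ccccc3s2)nn1` differs from compound 1 by 2,3-dihydroxypropyl in place of 4-bromophenyl on an aromatic nitrogen. Among the measured compounds shown here, no measured step swaps the whole ring for a chain; the nearest guides are no change at the digits printed from compound 1 to compound 2 (within the scatter) and a number 36.7 percentage points lower from compound 1 to compound 3 (beyond the scatter), which show that a change on that ring can leave the number alone or cut it sharply. A larger change is therefore expected to lower inhibition, with wide uncertainty, as a number 30 percentage points lower from compound 1 to compound 4 (beyond the scatter). Compound 4 is estimated at 45%, between 20% and 70%.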

Compound 4, a percentage reported as inhibition, in the whole organism at one dose (the size of the read-out at that dose, not a potency): 56.7%
Compound 4: middle estimate off by 11.7 percentage points, on the low side; the measured number falls inside the stated range.
By their numbers in this assay, from the lowest: compound 3; then compound 4; then compounds 1 and 2 (each within the scatter of the next).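

The 4-bromophenyl ring on this aromatic nitrogen can be replaced entirely without losing all inhibition. In this assay, the open 2,3-dihydroxypropyl chain gives a number 18.3 percentage points lower from compound 1 to compound 4 (beyond the scatter), so the aromatic ring at this position is not essential for the effect, although the number is lower without it. Nothing measured here explains this drop. Going by these compounds, it remains open whether a plain propyl chain would behave like the 2,3-dihydroxypropyl chain. A carboxylic acid or an amine at the end of a longer chain is also untested among the compounds shown.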